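From propoxy to methoxymethoxy: the step to compound 4

This account rests on a few compounds, and the source may have more. Where it says the series, first, only, none or still open, it means among the compounds named here.

Compound 1 `O=c1cc(N2CCNCC2)c2ccccc2o1`: 49000 nM
Compound 2 `CCCOc1ccc2c(N3CCNCC3)cc(=O)oc2c1C`: 2950 nM
Compound 3 `O=c1cc(N2CCNCC2)c2ccc(OCc3cccnc3)cc2o1`: 21300 nM

In a functional assay on a cell-free system (plasma, Homo sapiens) for inhibition, with Plasma (Rattus norvegicus) as the target (on this read-out higher numbers stand for weaker inhibition and lower numbers for stronger inhibition), compound 2 gives the lowest number of the three, 2950 nM, and the other two lie beyond the scatter from it. Compound 4 `COCOc1ccc2c(N3CCNCC3)cc(=O)oc2c1C` differs from compound 2 only in its chain: methoxy in place of ethyl on a saturated chain carbon bound to an oxygen on an aromatic ring. Propoxy thus becomes methoxymethoxy.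

For the measured compounds named here, no measured pair makes this swap. Going by the values given here, the one measured step, a 2.3-fold lower number from compound 1 to compound 3 (0.36 log units; beyond the scatter), was modest and puts a whole new group where hydrogen stood, so it is only a loose guide. It does show that a group joined through oxygen can shift the number. Compound 3 carries such a group yet reads 21300 nM, so an oxygen-linked group alone does not guarantee a number as low as that of compound 2. A small rise in this assay is expected, and it may well stay within the scatter. The expected change is a 1.5-fold higher number from compound 2 to compound 4 (0.18 log units; within the scatter). For compound 4 the estimated value is 4500 nM, with an expected range of 1800 nM to 12000 nM.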

Compound 4, half-maximal inhibitory concentration: 2300 nM
Estimate against measurement, compound 4: 2.0-fold (0.29 log units) above, within the range that was stated.
By their numbers in this assay, from the lowest: compounds 4 and 2 (each within the scatter of the next); then compound 3; then compound 1.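

In this assay, changing propoxy to methoxymethoxy gives a 1.3-fold lower number from compound 2 to compound 4 (0.11 log units; within the scatter), so this read-out cannot tell the two compounds apart. For the compounds shown here, this is the first measured change within the chain itself: methoxy enters with the same count of heavy atoms as the departing ethyl but adds one hydrogen-bond acceptor, and on a saturated chain carbon bound to an oxygen on an aromatic ring, that exchange produces no step beyond the scatter. No evidence is available to explain this result.

This single pair cannot show how much change this place on the chain accepts. A longer chain, an amine or a carboxylic acid in place of methoxy could give a different result, and the same holds for a hydroxyl group.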